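Removing a fluorine from the aryl terminus of a diaryl ether amide

The compounds below may be only part of what the source reports. "The series", "measured", "known", "first", "only" and "open" are said of these compounds alone.

Compound 1 `CNC(=O)c1cc(Oc2ccc(NC(=O)c3cc(-c4ccc(F)cc4)ncn3)cc2F)ccn1` is one of three compounds tested in a functional assay on A549 cells (Homo sapiens) for cytotoxicity, read by MTT assay, with a stated time of 72 h; a higher number here means a weaker inhibitor, a lower number a stronger inhibitor. In this assay compound 1 gives > 100000 nM, which is a limit of the measurement rather than a number. Compound 2 `CNC(=O)c1cc(Oc2ccc(NC(=O)c3cc(-c4ccc(C)cc4)ncn3)cc2)ccn1` gives > 100000 nM, likewise a limit. Compound 3 `CCc1ccc(-c2cc(C(=O)Nc3ccc(Oc4ccnc(C(=O)NC)c4)cc3)ncn2)cc1` gives 13300 nM. For the measured compounds named here, the one measured step, an at least 7.5-fold lower number from compound 2 to compound 3 (0.87 log units; beyond the scatter), concerns methyl in place of hydrogen on a saturated chain carbon bound to an aromatic carbon, and so two of the three values shown rest on (the limit of > 100000 nM in this assay, at which 2 of the 3 values shown sit).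

Compound 4 `CNC(=O)c1cc(Oc2ccc(NC(=O)c3cc(-c4ccccc4)ncn3)cc2F)ccn1` differs from compound 1 by hydrogen in place of fluoro on an aromatic carbon, para to a large group. Going by the values given here, no measured step addresses this change, and the only step available is in a different part of the core. Since compound 1 already stands at the limit, there is no measured value to move from; compound 2 and compound 3 show that a small change on the terminal aryl ring can shift the number beyond the scatter, but nothing shows which way this one goes. The expected step is therefore a number no higher from compound 1 to compound 4 (the limit leaves the size open), with compound 4 estimated at 100000 nM, between 30000 nM and 300000 nM.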

Compound 4, half-maximal inhibitory concentration: 23200 nM
The estimate for compound 4 lay 4.3-fold (0.63 log units) above the measured number, outside the stated range (below it).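

Replacing fluoro with hydrogen on the aryl terminus moves the core of compound 1 off the limit of this assay, giving an at least 4.3-fold lower number from compound 1 to compound 4 (0.63 log units; beyond the scatter), so this position can change the read-out even when the group that leaves is a single fluorine. Set beside an at least 7.5-fold lower number from compound 2 to compound 3 (0.87 log units; beyond the scatter), the new step shows no single direction with the size of the group: there a longer chain goes with the lower number, while here the loss of the substituent does, although compound 1 and compound 4 carry a further fluoro on the core that compound 2 and compound 3 lack. The value of compound 1 is a limit and not a number, so the true size of the step stays open: the limit of > 100000 nM in this assay, at which 2 of the 4 values shown sit.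

The compounds shown leave open whether the unsubstituted phenyl would give a similar number on the core without that further fluoro, since no pair isolates that fluoro. They also leave open how other groups at this place, such as chloro, methoxy, an amine or a carboxylic acid, would compare with hydrogen and ethyl.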